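Notes on compounds 1 to 3

The compounds below may be only part of what the source reports. "The series", "measured", "known", "first", "only" and "open" are said of these compounds alone.

Measured so far:
Compound 1, `O=C(Nc1cccc(NC(=O)c2cccc(C(F)(F)F)c2)c1)c1cccc(Cl)c1`, gives only an assay limit in an in vitro functional assay on HEK293-A cells for antagonist activity at metabotropic glutamate receptor 5 (Rattus norvegicus), read by calcium flux; a higher number here means a weaker inhibitor, a lower number a stronger inhibitor: > 30000 nM.
Compound 2, `O=C(Nc1cccc(O)c1)c1cccc(N2C(=O)c3ccccc3C2=O)c1`, gives in this assay 7790 nM.

For the measured compounds named here, compound 2 thus holds the only numeric value; the other entry is a limit, (the limit of > 30000 nM in this assay, at which 1 of the 2 values shown sits). Compound 3, `O=C(NC1CC2CCC1C2)c1cccc(N2C(=O)c3ccccc3C2=O)c1`, differs from compound 2 by a group of 7 heavy atoms (7 carbon; 2 five-membered non-aromatic rings of carbon only) in place of a group of 7 heavy atoms (6 carbon, 1 oxygen; one six-membered aromatic ring of carbon only), on an amide-type nitrogen. Going by the values given here, no step between measured compounds exists to calibrate this change. For compound 3 a step of a 1.9-fold higher number from compound 2 to compound 3 (0.28 log units; within the scatter) toward weaker inhibition is expected, with a fair chance of a limit. Compound 3 is estimated at 15000 nM, range 3000 nM to 30000 nM.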

Compound 3, half-maximal inhibitory concentration: > 30000 nM
Compound 3: only a limit was reported; the forecaster's own chance of this, stated with the estimate: 40%; middle value at least 2.0-fold (0.30 log units) from the limit.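

In this assay the exchange of 3-hydroxyphenyl for the all-carbon group with 2 five-membered non-aromatic rings, on the amide-type nitrogen, gives an at least 3.8-fold higher number from compound 2 to compound 3 (0.58 log units; beyond the scatter) with the rest of the structure unchanged. For the compounds shown here, this is the first step that can be read at this position, and it lies beyond the scatter. The entry for compound 3 is a limit, and the step has a floor but no measured size: the limit of > 30000 nM in this assay, at which 2 of the 3 values shown sit.

Open, as far as these compounds go, is how an aminophenyl, a carboxyphenyl or a straight alkyl chain on this nitrogen would read in this assay and whether the hydroxyl or the aromatic ring of compound 2 accounts for the difference.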